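Working notes on a three-compound antiproliferative series and compound 4

The compounds below may be only part of what the source reports. "The series", "measured", "known", "first", "only" and "open" are said of these compounds alone.

Measured in a functional assay on HeLa cells (Homo sapiens) for antiproliferative activity, with a stated time of 24 h; on this read-out lower numbers stand for stronger inhibition and higher numbers for weaker inhibition:
compound 1 `NC(=O)c1c(NC(=O)c2ccccc2Cl)sc2c1CCN(Cc1ccc(Cl)cc1Cl)C2`: 21100 nM
compound 2 `NC(=O)c1c(NC(=O)c2ccccc2Cl)sc2c1CCN(C(=O)Nc1ccccc1Cl)C2`: 45400 nM
compound 3 `NC(=O)c1c(NC(=O)c2ccccc2Cl)sc2c1CCN(C(=S)Nc1ccccc1I)C2`: 29000 nM

Compound 3 sits second highest of the three numbers; its neighbours lie within the scatter on either side, as a 1.4-fold higher number from compound 1 to compound 3 (0.14 log units; within the scatter) and a 1.6-fold lower number from compound 2 to compound 3 (0.19 log units; within the scatter) show. For the measured compounds named here, the only step beyond the scatter is a 2.2-fold higher number from compound 1 to compound 2 (0.33 log units; beyond the scatter), and it concerns the amine nitrogen in the ring, not the amide-type nitrogen.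

Compound 4 `NC(=O)c1c(NC(=O)c2ccccc2Cl)sc2c1CCN(C(=S)Nc1c(Cl)cccc1Cl)C2` differs from compound 3 by 2,6-dichlorophenyl in place of 2-iodophenyl on an amide-type nitrogen. Going by the values given here, no measured step alters the aryl on the thiocarbonyl-bearing nitrogen, so the expectation rests on the spread of the three values, which all lie close. The expected step of a 1.0-fold higher number from compound 3 to compound 4 (0.01 log units; within the scatter) is none beyond the scatter. Compound 4 is estimated at 30000 nM in this assay, within 12000 nM to 75000 nM.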

Compound 4, half-maximal inhibitory concentration: 26500 nM
Compound 4: middle estimate off by 1.1-fold (0.05 log units), on the high side, and the stated range covers the measured number.
By their numbers in this assay, from the lowest: compounds 1, 4, 3 and 2 (each within the scatter of the next, the first and the last beyond it).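

In this assay, 2,6-dichlorophenyl in place of 2-iodophenyl on this amide-type nitrogen gives a 1.1-fold lower number from compound 3 to compound 4 (0.04 log units; within the scatter), the only step shown that alters this phenyl, and the read-out does not separate the two halogen patterns. Compound 4 also stays within the scatter of the other two compounds, with a 1.7-fold lower number from compound 2 to compound 4 (0.23 log units; within the scatter) and a 1.3-fold higher number from compound 1 to compound 4 (0.10 log units; within the scatter). No evidence bears on why this change leaves the number in place.

Every group shown on this nitrogen is a halogen-bearing phenyl. As far as these compounds go, whether an amine or a carboxylic acid in place of the 2,6-dichlorophenyl would move the number remains open.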